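The source may hold more compounds than are shown below. What is called first, only, known or untested is meant among the compounds shown, and "the series" means these compounds.

Measured so far in an ADME assay on Huh-7 cells (Homo sapiens) for cytotoxicity; on this read-out higher numbers stand for lower toxicity in this test and lower numbers for higher toxicity in this test:
- compound 1, `Cc1ccccc1-c1nn(-c2cc(F)ccc2F)cc1CNCCN1CCN(C)CC1`: > 20000 nM
- compound 2, `Cc1ccc(-n2cc(CNCCN3CCN(C)CC3)c(-c3ccccc3C)n2)c(C)c1`: > 20000 nM
- compound 3, `Cc1ccccc1-c1nn(-c2ccc(C(F)(F)F)cc2)cc1CNCCN1CCN(C)CC1`: 11000 nM

Compound 1 gives only a limit of this assay, > 20000 nM. Compound 2 likewise gives only a limit, > 20000 nM. Among the compounds with values here, compound 3 is the one compound with a number, 11000 nM, and so stands as the only fixed point among the three; the other two sit at the limit of > 20000 nM in this assay, at which 2 of the 3 values shown sit.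

Compound 4, `Cc1ccccc1-c1nn(-c2ccc(N)cc2)cc1CNCCN1CCN(C)CC1`, is not yet measured. It differs from compound 3 by amino in place of trifluoromethyl on an aromatic carbon. Within the data shown here, the measured steps that change the ring on the aromatic nitrogen are an at least 1.8-fold lower number from compound 1 to compound 3 (0.25 log units; that floor lies within the scatter) and an at least 1.8-fold lower number from compound 2 to compound 3 (0.25 log units; that floor lies within the scatter), both of which carried the values from a limit down to the one number, while a step that the two limits leave unreadable from compound 1 to compound 2 stays unreadable between two limits. None of these steps touches the aromatic carbon that changes here, so they give only a loose guide. Taking away the trifluoromethyl that marks compound 3 apart from the two limit compounds, the expected step is a 1.8-fold higher number from compound 3 to compound 4 (0.26 log units; within the scatter), back toward the limit and probably not beyond the scatter. Compound 4 is therefore estimated at 20000 nM, within 8000 nM to 50000 nM.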

Compound 4, half-maximal cytotoxic concentration: > 20000 nM
Compound 4 was reported as a limit; the forecaster's own chance of this, stated with the estimate: 55%; the middle value lies on the limit itself.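

The earlier compounds shown here changed the whole ring on the aromatic nitrogen, whereas this change replaces a single group on an aromatic carbon of that ring, and in this assay it reads as an at least 1.8-fold higher number from compound 3 to compound 4 (0.25 log units; that floor lies within the scatter). Since that floor lies within the scatter and compound 4 gives only a limit, the data do not establish that amino in place of trifluoromethyl shifts the read-out, only that the amino compound joins the others at the limit: the limit of > 20000 nM in this assay, at which 3 of the 4 values shown sit.

Within the data shown here, compound 3, with its 4-(trifluoromethyl)phenyl, therefore remains the only compound with a number, while the steps from compound 1 and compound 2 to compound 4 cannot be read, as both ends are limits.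

As far as these compounds go, it remains open whether another group on this aromatic carbon, such as chlorine, a methoxy group or a carboxylic acid, would give a number in this assay, and how far any of the limit compounds lie from compound 3. From the compounds shown here alone, it is also open whether the number seen for compound 3 would hold with a longer chain between the shared core and its terminal amine.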